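Benzoyl for thiophen-2-ylcarbonyl: a cautious expectation

The source may hold more compounds than are shown below. What is called first, only, known or untested is meant among the compounds shown, and "the series" means these compounds.

Compound 1 `COc1cc(-c2nnc3n2NC(c2ccco2)C(C(=O)c2cccs2)S3)cc(OC)c1OC` was tested in a functional assay on PC-3 cells (Homo sapiens) for cytotoxicity, read by MTT assay, with a stated time of 48 h; a higher number here means a weaker inhibitor, a lower number a stronger inhibitor; there compound 1 gives 46200 nM, the highest of the two numbers reported. Its nearest neighbour is compound 2 `COc1cc(-c2nnc3n2NC(c2cccs2)C(C(=O)c2ccc(F)cc2)S3)cc(OC)c1OC`, and in that assay compound 2 gives 27400 nM, a gap that lies within the scatter, so no order between the two can be claimed. Compound 3 `COc1cc(C(=O)C2Sc3nnc(-c4cc(OC)c(OC)c(OC)c4)n3NC2c2cccs2)cc(OC)c1OC` reaches only a limit of the assay, > 100000 nM. Among the measured compounds shown here, the one step measured in a single place is an at least 3.6-fold higher number from compound 2 to compound 3 (0.56 log units; beyond the scatter), and the limit of > 100000 nM in this assay, at which 1 of the 3 values shown sits, caps how large that step can be read.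

Compound 4 `COc1cc(-c2nnc3n2NC(c2ccco2)C(C(=O)c2ccccc2)S3)cc(OC)c1OC` differs from compound 1 by phenyl in place of thiophen-2-yl on a carbonyl carbon. For the measured compounds named here, no measured step exchanges these two groups; the step from compound 2 to compound 3 sits on the same carbonyl carbon but swaps other rings, so it bears only loosely on this change. Compound 4 is therefore expected to show a 1.2-fold lower number from compound 1 to compound 4 (0.06 log units; within the scatter), not beyond the scatter. The estimate for compound 4 in this assay is 40000 nM, within a range from 15000 nM to 100000 nM.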

Compound 4, half-maximal inhibitory concentration: 64300 nM
Compound 4: the middle estimate sits 1.6-fold (0.21 log units) below what was measured; measured number inside the range.
By their numbers in this assay, from the lowest: compounds 2, 1 and 4 (each within the scatter of the next, the first and the last beyond it). At a limit, above all of these: compound 3.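

Among the compounds shown here, the step of a 1.4-fold higher number from compound 1 to compound 4 (0.14 log units; within the scatter), read in this assay, is the first direct reading of this exchange on a carbonyl carbon whose other neighbour is a saturated ring carbon, and it does not separate the two rings. For the compounds shown here, the only earlier step at this carbon, an at least 3.6-fold higher number from compound 2 to compound 3 (0.56 log units; beyond the scatter), lay beyond the scatter but carried 3,4,5-trimethoxyphenyl in place of 4-fluorophenyl, so it could not show how the unsubstituted phenyl and thiophen-2-yl compare. Nothing shown here offers a measured property that bears on this result.

The compounds shown leave open whether a saturated ring such as cyclohexyl, or a chain such as n-butyl, would read differently on this carbonyl carbon. They also leave open what a single methoxy or chloro group on the phenyl of compound 4 would do.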